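From a Hydroxyphenyl Ring to a Phenylethenyl Chain

The compounds below may be only part of what the source reports. "The series", "measured", "known", "first", "only" and "open" are said of these compounds alone.

Of the compounds shown here, two sharing one core have been measured so far. Compound 1 `NS(=O)(=O)c1ccc(N2N=C(c3cccc(O)c3)C[C@H]2c2ccccc2)cc1` gives 77.7% in a functional assay on the whole organism (strain Wistar albino) for inhibition, with Rattus norvegicus as the target, read by paw edema, with stated times of 30 min and 5 h, at a dose of 0.05 mmol/kg; on this read-out higher numbers stand for more inhibition at the one dose given (going by the name of the read-out) and lower numbers for less inhibition. Compound 2 `NS(=O)(=O)c1ccc(N2N=C(c3cccc(O)c3)C[C@H]2c2ccccc2O)cc1`, which differs from it by a hydroxy in place of hydrogen on an aromatic carbon, gives 55.5% in this assay and stands as the lower of the two numbers, with a number 22.2 percentage points lower from compound 1 to compound 2 (beyond the scatter).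

Compound 3 `NS(=O)(=O)c1ccc(N2N=C(c3cccc(O)c3)C[C@H]2/C=C/c2ccccc2)cc1` is not yet measured. Relative to compound 2 the change is 2-phenylethenyl in place of 2-hydroxyphenyl on a saturated ring carbon. For the measured compounds named here, the only measured step that bears on this change is the one from compound 1 to compound 2, since compound 3 again lacks the hydroxy that set compound 2 below compound 1. Going by the values given here, the phenylethenyl group itself has no precedent among the measured compounds, so that part of the change is open. On balance, the expected step is a number 12.5 percentage points higher from compound 2 to compound 3 (beyond the scatter), a partial return toward the number of compound 1. Compound 3 is therefore estimated to give 68% in this assay, with a range from 50% to 84%.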

Compound 3, a percentage reported as inhibition, in the whole organism at one dose (the size of the read-out at that dose, not a potency): 59.2%
Compound 3: the middle estimate sits 8.8 percentage points above what was measured; low and high end bracket the measured number.
By their numbers in this assay, from the lowest: compounds 2 and 3 (each within the scatter of the next); then compound 1.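

Replacing 2-hydroxyphenyl with 2-phenylethenyl on this saturated ring carbon, next to the ring nitrogen, removes the hydroxy and adds a double bond outside the aromatic rings, yet it gives a number 3.7 percentage points higher from compound 2 to compound 3 (within the scatter) in this assay, so this assay does not separate the two groups. The comparison with phenyl gives a number 18.5 percentage points lower from compound 1 to compound 3 (beyond the scatter), which shows that a number below that of compound 1 at this position does not require a hydroxy, since the 2-phenylethenyl group carries none. Nothing available accounts for why either replacement stands below phenyl.

The compounds shown leave open whether the double bond itself matters, which a saturated 2-phenylethyl chain on the same carbon could test, and whether a hydroxy on the aromatic ring of the 2-phenylethenyl group would shift the number. Also open, going by these compounds, is how this position would respond to a small methyl group or to a chain ending in an amine or a carboxylic acid, and whether the phenyl of compound 1 would keep its place among such groups.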